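The source may hold more compounds than are shown below. What is called first, only, known or untested is meant among the compounds shown, and "the series" means these compounds.

Measured so far in a functional assay on HepG2 cells (Homo sapiens) for inhibition, read by MTT assay, with a stated time of 48 h; a lower number here means a stronger inhibitor, a higher number a weaker inhibitor:
Compound 1, `COc1cc2cc(NC(C)=O)c(=O)oc2cc1OCCOc1no[n+]([O-])c1S(=O)(=O)c1ccccc1`, gives 4830 nM.
Compound 2, `COc1cc2cc(NC(C)=O)c(=O)oc2cc1OCCCCOc1no[n+]([O-])c1S(=O)(=O)c1ccccc1`, gives 3290 nM.
Compound 3, `COc1cc2cc(N)c(=O)oc2cc1OCCOc1no[n+]([O-])c1S(=O)(=O)c1ccccc1`, gives 3060 nM.

Compound 3 differs from compound 1 in one place: hydrogen in place of acetyl on a nitrogen on an aromatic ring. That step reads a 1.6-fold lower number from compound 1 to compound 3 (0.20 log units; within the scatter). Compound 2 and compound 1 differ more broadly; the difference between the two cores is not broken down here, and their two numbers sit within the scatter of each other.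

Compound 4, `COc1cc2cc(N)c(=O)oc2cc1OCCCCOc1no[n+]([O-])c1S(=O)(=O)c1ccccc1`, is not yet measured. It differs from compound 2 in one place: hydrogen in place of acetyl on a nitrogen on an aromatic ring. The surroundings of the place agree word for word with those of the earlier change, so this is the same change as that from compound 1 to compound 3, now made on the core of compound 2. Within the data shown here, only one earlier example of the change exists, and that one lies within the scatter, so the expectation rests on it alone. In this assay the step is expected to be about as small, at roughly a 1.3-fold lower number from compound 2 to compound 4 (0.12 log units; within the scatter), because the earlier one reads a 1.6-fold lower number from compound 1 to compound 3 (0.20 log units; within the scatter). Compound 4 is therefore estimated at 2500 nM, with a range from 1200 nM to 5200 nM.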

Compound 4, half-maximal inhibitory concentration: 2640 nM
Compound 4: the middle estimate sits 1.1-fold (0.02 log units) below what was measured; the measured number falls inside the stated range.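

In this assay, hydrogen in place of acetyl on the core of compound 2 reads a 1.2-fold lower number from compound 2 to compound 4 (0.10 log units; within the scatter), and this step cannot be told apart from the earlier one on the core of compound 1: the same change on two cores in this assay, a 1.6-fold lower number (0.20 log units; within the scatter) from compound 1 to compound 3 and a 1.2-fold lower number (0.10 log units; within the scatter) from compound 2 to compound 4, 1.3-fold (0.10 log units) apart, within the scatter of two such steps. The acetamido to amino change therefore behaves alike on these two cores, with no departure on either that stands clear of the scatter. Among these compounds, since both steps lie within the scatter, this agreement shows only that neither core gives a readable effect of the change, not that amino and acetamido differ in inhibition, and two cores say nothing about how the change would read on any other core.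

The compounds shown leave open whether a different group on that nitrogen, such as a benzoyl group, a sulfonyl group or a urea, would give a step beyond the scatter. Among the compounds shown here, also open is how a longer chain than the one in compound 2 would read in this assay, with either amino or acetamido in place.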